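Pyrazine for pyrazole on the amide nitrogen

The source may report more compounds than this note shows. Statements on the series, on what has been measured and on what is new or still open speak of the compounds shown alone.

Measured compounds:
compound 1 `CCN(C(=O)CN(c1cc(N(C)C)ccc1Cl)S(=O)(=O)c1ccc(OC)c(OC)c1)c1cccc(C)n1`: 5 nM
compound 2 `CCN(C(=O)CN(c1cc(N(C)C)ccc1Cl)S(=O)(=O)c1ccc(OC)c(OC)c1)c1ccn(C)n1`: 7 nM
compound 3 `CCN(CC)C(=O)CN(c1ccc(C)cc1)S(=O)(=O)c1ccccc1F`: 3370 nM

In a functional assay on CHO cells for inhibition of Orexin receptor type 2 (Homo sapiens), read by FLIPR and calcium flux (a lower number here means a stronger inhibitor, a higher number a weaker inhibitor), compound 2 gives 7 nM, the second highest of the three numbers; compound 1 is nearest, compound 3 furthest, with a gap beyond the scatter. Compound 4 `CCN(C(=O)CN(c1cc(N(C)C)ccc1Cl)S(=O)(=O)c1ccc(OC)c(OC)c1)c1cnc(C)cn1` is unmeasured. It differs from compound 2 by 5-methylpyrazin-2-yl in place of 1-methyl-1H-pyrazol-3-yl on an amide-type nitrogen. Within the data shown here, the one step that bears on this place, a 1.4-fold higher number from compound 1 to compound 2 (0.15 log units; within the scatter), exchanged a six-membered aromatic ring for the five-membered one and stayed within the scatter. The return to a six-membered aromatic ring with two hetero atoms is therefore expected to give no step beyond the scatter, a 1.1-fold higher number from compound 2 to compound 4 (0.06 log units; within the scatter). Compound 4 is estimated at 8 nM in this assay, between 3 nM and 25 nM.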

Compound 4, half-maximal inhibitory concentration: 3 nM
Compound 4: middle estimate off by 2.7-fold (0.43 log units), on the high side; the measured number falls inside the stated range.
By their numbers in this assay, from the lowest: compounds 4, 1 and 2 (each within the scatter of the next, the first and the last beyond it); then compound 3.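

In this assay, among these compounds, 5-methylpyrazin-2-yl on the amide-type nitrogen gives the first step beyond the scatter at this position, though a modest one (a 2.3-fold lower number from compound 2 to compound 4 (0.37 log units; beyond the scatter)). Set against 6-methylpyridin-2-yl, the same group stays within the scatter (a 1.7-fold lower number from compound 1 to compound 4 (0.22 log units; within the scatter)), so the position separates it only from 1-methyl-1H-pyrazol-3-yl, and narrowly. Nothing measured here accounts for this difference. The compounds shown leave open whether an amine or a carboxylic acid on the 5-methylpyrazin-2-yl ring in place of its methyl, or a propyl chain in place of the ethyl on the amide-type nitrogen, would hold these numbers.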